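From Dimethylamino to Methoxy: One Change, Lipophilicity Expected

The compounds below may be only part of what the source reports. "The series", "measured", "known", "first", "only" and "open" are said of these compounds alone.

Compound 1 `CC[C@@H](Nc1c(C#N)c(-c2ccc(-c3ccccc3N(C)C)cc2)nc2cnccc12)C(N)=O` is the more lipophilic of the two measured compounds: in a physicochemical assay for lipophilicity, read by HPLC, at pH 7.5 (on this read-out lower numbers stand for lower lipophilicity and higher numbers for higher lipophilicity), compound 1 gives 3.2, while compound 2 `CC[C@@H](Nc1c(C#N)c(-c2ccc(-c3cccc(C)c3F)cc2)nc2cnccc12)C(=O)O` gives 2.1, a gap beyond the usual scatter. Compound 3 `CC[C@@H](Nc1c(C#N)c(-c2ccc(-c3ccccc3OC)cc2)nc2cnccc12)C(N)=O` differs from compound 1 in a single place: methoxy in place of dimethylamino on an aromatic carbon. For the measured compounds named here, no measured pair shows this exact change, so the expectation rests on the change itself. A small downward step is expected, a number 0.30 log units lower from compound 1 to compound 3 (within the scatter), likely within the scatter. Compound 3 is therefore estimated at 2.9, in a range from 2.5 to 3.3.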

Compound 3, distribution coefficient: 2.7
For compound 3 the middle estimate is 0.20 log units above the measured one; the range from low to high includes it.
By their numbers in this assay, from the lowest: compound 2; then compound 3; then compound 1.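

In this assay, methoxy in place of dimethylamino on this aromatic carbon, ortho to a large group, gives a number 0.50 log units lower from compound 1 to compound 3 (beyond the scatter). For the compounds shown here, this is the first measured step at this position, and with the rest of the molecule unchanged, it shows that this single change is enough to move the read-out past the usual scatter. Nothing available explains the size or direction of the step.

Where a hydroxyl or an ethoxy group at this position would fall remains open. A single step also cannot show whether the same change would act alike elsewhere on the molecule.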